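Swapping a Phenol Hydroxy for Dimethylamino

The compounds below may be only part of what the source reports. "The series", "measured", "known", "first", "only" and "open" are said of these compounds alone.

Of the compounds shown here, three have been measured in an ADME assay on MCF7 cells for inhibition of cytochrome P450 26A1 (Homo sapiens); a lower number here means a stronger inhibitor, a higher number a weaker inhibitor. Compound 1 `COc1ccc2c(c1)CC/C(=C\c1ccccc1C)C2=O` gives 20000 nM. Compound 2 `COc1ccc2c(c1)CCC(Cc1ccc(O)cc1)C2=O` gives 5000 nM in this assay. Compound 3 `O=C1c2ccc(O)cc2CCC1Cc1ccc(O)cc1` gives 20000 nM in this assay. Going by the values given here, the single measured step between neighbours that differ in one place runs from compound 2 to compound 3, where hydrogen replaces methyl on an oxygen on an aromatic ring, with a 4.0-fold higher number from compound 2 to compound 3 (0.60 log units; beyond the scatter). Compound 3 therefore stands, as far as the digits go, level with compound 1, the two of them sharing the highest number of the three and lying within the scatter of each other, while compound 2 sits a modest step lower.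

Compound 4 `CN(C)c1ccc(CC2CCc3cc(O)ccc3C2=O)cc1` has not yet been measured in this assay. It differs from compound 3 by dimethylamino in place of hydroxy on an aromatic carbon of a six-membered aromatic ring of carbon only. Among the compounds with values here, no measured step touches this group: the step from compound 2 to compound 3 concerns an oxygen on the other aromatic ring of the shared core and was modest, so it offers no direct guide. With nothing else to draw on, the expected step in this assay is a 1.3-fold lower number from compound 3 to compound 4 (0.12 log units; within the scatter), not clearly beyond the scatter. Compound 4 is therefore estimated at 15000 nM, with a range from 4000 nM to 60000 nM.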

Compound 4, half-maximal inhibitory concentration: 25000 nM
The estimate for compound 4 lay 1.7-fold (0.22 log units) below the measured number; low and high end bracket the measured number.
By their numbers in this assay, from the lowest: compound 2; then compounds 1, 3 and 4 (each within the scatter of the next).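

In this assay, going by these compounds alone, putting dimethylamino in place of hydroxy on this aromatic carbon, para to a large group, gives a 1.3-fold higher number from compound 3 to compound 4 (0.10 log units; within the scatter), the first reading at this position. The exchange swaps a group of 1 heavy atom and 1 hydrogen-bond donor for one of 3 heavy atoms and 0 hydrogen-bond donors, yet compound 3 at 20000 nM and compound 4 at 25000 nM cannot be told apart, so on this core the assay does not separate these two groups at this position. No measured information is available to explain this outcome.

As far as these compounds go, it remains open whether a different group at this same position, such as a primary amine or a carboxylic acid, would move the number beyond the scatter. From the compounds shown here alone, it also remains open whether the dimethylamino exchange would read the same on compound 2, which keeps the methyl on the oxygen of the other aromatic ring and has the lower number of the pair linked by a 4.0-fold higher number from compound 2 to compound 3 (0.60 log units; beyond the scatter).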